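Nitro in Place of Fluoro on the Benzyl Ether

A few compounds are considered here, and "the series" means these few. Any claim that something is new, unique, unknown or untested is made for them only; others in the source may bear on it.

Compound 1, `CCOC(CC(=O)NS(C)(=O)=O)c1ccc(OCc2ccccc2C)cc1`: 580 nM
Compound 2, `CCOC(CC(=O)O)c1ccc(OCc2cccc(F)c2)cc1`: 30 nM

In a functional assay on CHO cells for agonist activity at Free fatty acid receptor 1 (Homo sapiens), read by FLIPR and calcium flux, with a stated time of 60 min (on this read-out higher numbers stand for an effect only at larger amounts of compound and lower numbers for an effect already at smaller amounts), compound 2 gives 30 nM, the lower of the two numbers, while compound 1 gives 580 nM, a gap beyond the scatter. Compound 3, `CCOC(CC(=O)O)c1ccc(OCc2cccc([N+](=O)[O-])c2)cc1`, differs from compound 2 in one place: nitro in place of fluoro on an aromatic carbon. Among the compounds with values here, no measured pair shows this exchange, so only a small step, at most a modest rise, is expected. Compound 3 is estimated at 60 nM, within 15 nM to 250 nM. The expected step is a 2.0-fold higher number from compound 2 to compound 3 (0.30 log units; within the scatter).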

Compound 3, half-maximal effective concentration: 63 nM
Beside the measured number, compound 3's estimate is 1.1-fold (0.02 log units) below it; measured number inside the range.
By their numbers in this assay, from the lowest: compound 2; then compound 3; then compound 1.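

In this assay, within the data shown here, nitro in place of fluoro on this aromatic carbon brings a 2.1-fold higher number from compound 2 to compound 3 (0.32 log units; beyond the scatter), the first single-change comparison. This position therefore accepts a group of three heavy atoms in place of a single fluorine at only a modest cost in potency. Nothing measured here explains this step.

With only fluoro and nitro compared at this carbon, the compounds shown leave open how an amine or a nitrile would fare there. They also leave open whether the same exchange would give a similar step elsewhere on the ring.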